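Halogen swap on the fused ring of compound 3

This account rests on a few compounds, and the source may have more. Where it says the series, first, only, none or still open, it means among the compounds named here.

Three members of the series have been through an ADME assay on HaCaT cells (Homo sapiens) for cytotoxicity, read by MTT assay, with a stated time of 48 h; a lower number here means a stronger inhibitor, a higher number a weaker inhibitor. Compound 1 `O=Cc1cn(-c2ccccc2)nc1-c1ccc(Cl)cc1` reaches only the limit of the assay, not a number, at > 50000 nM. Compound 2 `c1ccc(-c2nn(-c3ccccc3)cc2-c2nc3ccccc3[nH]2)cc1` likewise stops at a limit, > 50000 nM. Compound 3 `Fc1ccc2[nH]c(-c3cn(-c4ccccc4)nc3-c3ccccc3)nc2c1` also returns a limit rather than a number, > 50000 nM. All three therefore sit at the limit of > 50000 nM in this assay, at which 3 of the 3 values shown sit, and the step that the two limits leave unreadable from compound 2 to compound 3, fluoro in place of hydrogen on an aromatic carbon, has no readable size because the limit of > 50000 nM in this assay, at which 3 of the 3 values shown sit, covers both of its ends. Compound 3 thus stands nowhere distinguishable among the values shown: every one is a limit at the same ceiling.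

Compound 4 `Brc1ccc2[nH]c(-c3cn(-c4ccccc4)nc3-c3ccccc3)nc2c1` is not yet measured. It differs from compound 3 by bromo in place of fluoro on an aromatic carbon. Going by the values given here, the only measured step in this part of the series is the unreadable one from compound 2 to compound 3, so no step of known size bears on a bromo-for-fluoro exchange. With three of three values at the ceiling, the expectation in this assay is no step beyond the scatter and most likely another limit. Compound 4 is estimated at 50000 nM, with a range from 20000 nM to 100000 nM. The expected step is a number no higher from compound 3 to compound 4 (the limit leaves the size open).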

Compound 4, half-maximal inhibitory concentration: > 50000 nM
Compound 4 was reported as a limit; the forecaster's own chance of this, stated with the estimate: 80%; the middle value lies on the limit itself.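

No new step can be read from compound 4: its steps from compound 2 and from compound 3 both have limits at each end, because all values share one ceiling: the limit of > 50000 nM in this assay, at which 4 of the 4 values shown sit.

Open remains whether compound 2, compound 3 and compound 4 differ at all in this assay, and what number, if any, each would give.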